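A few compounds are considered here, and "the series" means these few. Any claim that something is new, unique, unknown or untested is made for them only; others in the source may bear on it.

Compound 3 `N#Cc1ccc(C(=O)Nc2cccc(-c3oc4cc(-c5ccc(F)cc5)ccc4c(=O)c3O)c2)cc1` gives 2360 nM in a functional assay on A549 cells (Homo sapiens) for antiproliferative activity, read by CCK-8 assay, with a stated time of 72 h (a lower number here means a stronger inhibitor, a higher number a weaker inhibitor), the lowest of the two numbers shown. Compound 1 `O=C(Nc1cccc(-c2oc3cc(-c4ccc(F)cc4)ccc3c(=O)c2O)c1)c1ccc(F)cc1F` gives 20500 nM in this assay. For compound 2 `O=C(Nc1cccc(-c2oc3cc(-c4ccc(F)cc4)ccc3c(=O)c2O)c1)c1cnc(Cl)nc1Cl` the reading in this assay is only a limit, > 100000 nM (the limit of > 100000 nM in this assay, at which 1 of the 3 values shown sits). Compound 4 `CCCc1ccc(C(=O)Nc2cccc(-c3oc4cc(-c5ccc(F)cc5)ccc4c(=O)c3O)c2)cc1` differs from compound 3 by propyl in place of cyano on an aromatic carbon. The measured steps that bear on this change all alter the group on the carbonyl carbon: an 8.7-fold lower number from compound 1 to compound 3 (0.94 log units; beyond the scatter), an at least 42-fold lower number from compound 2 to compound 3 (1.62 log units; beyond the scatter) and an at least 4.8-fold higher number from compound 1 to compound 2 (0.68 log units; beyond the scatter). They show that changing this group moves the number widely, in either direction, so a shift beyond the scatter is expected here too. Compound 4 is expected to give a higher number than compound 3, by a 2.5-fold higher number from compound 3 to compound 4 (0.41 log units; beyond the scatter), with an estimate of 6000 nM, between 1500 nM and 30000 nM.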

Compound 4, half-maximal inhibitory concentration: 47600 nM
Beside the measured number, compound 4's estimate is 7.9-fold (0.90 log units) below it; the whole stated range lies below it.
By their numbers in this assay, from the lowest: compound 3; then compound 1; then compound 4. At a limit, above all of these: compound 2.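

Compound 3 and compound 4 differ only on an aromatic carbon para to a large group, and that single exchange of cyano for propyl gives a 20-fold higher number from compound 3 to compound 4 (1.30 log units; beyond the scatter), so this one position alone moves the number as much as replacing the whole group on the carbonyl carbon. A 4-substituted phenyl does not itself secure a low number: a 2.3-fold higher number from compound 1 to compound 4 (0.37 log units; beyond the scatter). The reading of compound 2 is only a limit, so an at least 2.1-fold lower number from compound 2 to compound 4 (0.32 log units; beyond the scatter) is a bound: the limit of > 100000 nM in this assay, at which 1 of the 4 values shown sits.

Open, going by these compounds, is how a shorter chain such as methyl, an amine or a carboxylic acid would read at this position.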